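This account rests on a few compounds, and the source may have more. Where it says the series, first, only, none or still open, it means among the compounds named here.

Compounds measured:
compound 1, `CCCCN(C)Cc1c(C(F)(F)F)nc2n(-c3c(C)cc(C)cc3C)c(Cl)cn12`: 310 nM
compound 2, `Cc1cc(C)c(-n2c(Cl)cn3c(CN(CCC(F)(F)F)Cc4ccc(F)cc4)c(C(F)(F)F)nc23)c(C)c1`: 34 nM

In an assay on cells for displacement of a labelled ligand from corticotropin-releasing factor receptor 1 (Homo sapiens), with a stated time of 100 min (a higher number here means a weaker inhibitor, a lower number a stronger inhibitor), compound 1 gives 310 nM, the higher of the two numbers shown. Compound 2 gives 34 nM in this assay, a gap that lies beyond the usual scatter of repeated measurements. The pair differ in more than one place, so no single change accounts for the gap.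

Compound 3, `CCN(Cc1ccccc1)Cc1c(C(F)(F)F)nc2n(-c3c(C)cc(C)cc3C)c(Cl)cn12`, has not yet been measured. It differs from compound 1 in one place: benzyl(ethyl)amino in place of butyl(methyl)amino on a saturated chain carbon bound to an aromatic carbon. Compound 2 also carries a benzyl group on the amine nitrogen, and its value of 34 nM is the lower of the two shown, so a move toward a lower number is expected for compound 3, though the size of that move is uncertain with two compounds only.

The expected step from compound 1 to compound 3 in this assay is a 4.4-fold lower number from compound 1 to compound 3 (0.65 log units; beyond the scatter). Compound 3 is estimated at 70 nM, with a range from 20 nM to 250 nM.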

Compound 3, inhibition constant: 350 nM
The estimate for compound 3 lay 5.0-fold (0.70 log units) below the measured number; the whole stated range lies below it.
By their numbers in this assay, from the lowest: compound 2; then compounds 1 and 3 (each within the scatter of the next).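

In this assay, benzyl(ethyl)amino in place of butyl(methyl)amino on a saturated chain carbon bound to an aromatic carbon gives a 1.1-fold higher number from compound 1 to compound 3 (0.05 log units; within the scatter), so at this position the larger group with its six-membered aromatic ring leaves the number unchanged within the scatter. A benzyl group on the amine nitrogen therefore does not by itself bring the number down to that of compound 2 at 34 nM. No measurement at hand explains why these two amines read alike.

The compounds shown do not separate the benzyl group from the ethyl group, and benzyl(methyl)amino or butyl(ethyl)amino on the same carbon would pull the two apart. They also leave open which other part of the amine of compound 2 goes with its number, and how a morpholine ring would read at this position.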